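The compounds below may be only part of what the source reports. "The series", "measured", "known", "first", "only" and "open" are said of these compounds alone.

For the measured compounds named here, compound 1 `O=S(=O)(Nc1ccc2oc(-c3ccccc3)nc2c1)c1ccccc1O` is the one member of this small set with a measured number: in an assay on cells for inhibition of HSP60/HSP10 (Homo sapiens), with a stated time of 60 min (on this read-out higher numbers stand for weaker inhibition and lower numbers for stronger inhibition), compound 1 gives 85000 nM. Compound 2 `O=S(=O)(Nc1ccc2oc(-c3ccccc3)nc2c1)c1ccc(Cl)c(Cl)c1` reaches only the limit of the assay, and in this assay compound 2 gives > 100000 nM. Compound 3 `Cc1ccccc1S(=O)(=O)Nc1ccc2oc(-c3ccccc3)nc2c1` likewise sits at the limit, so that in this assay compound 3 gives > 100000 nM. Compound 3 therefore stands at the limit, as described in the limit of > 100000 nM in this assay, at which 2 of the 3 values shown sit. The change to compound 4 `O=S(=O)(Nc1ccc2oc(-c3ccccc3)nc2c1)c1ccccc1C(F)(F)F` is trifluoromethyl in place of methyl on an aromatic carbon. Of the measured steps, an at least 1.1-fold higher number from compound 1 to compound 3 (0.07 log units; that floor lies within the scatter) touches the same aromatic carbon, while a step that the two limits leave unreadable from compound 2 to compound 3 replaces the aryl on the sulfonyl sulfur. Neither fixes a size, and no trifluoromethyl appears in the set, so compound 4 is expected to stay near the limit, with a number no higher from compound 3 to compound 4 (the limit leaves the size open). Compound 4 is estimated at 100000 nM, between 30000 nM and 300000 nM.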

Compound 4, half-maximal inhibitory concentration: > 100000 nM
Compound 4: a limit, no number; the forecaster's own chance of this, stated with the estimate: 70%; the middle value lies on the limit itself.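

Trifluoromethyl on this aromatic carbon, ortho to a large group, brings a second replacement of hydroxy to the limit, and a limit is not a number: the limit of > 100000 nM in this assay, at which 3 of the 4 values shown sit. Set against hydroxy, trifluoromethyl gives an at least 1.1-fold higher number from compound 1 to compound 4 (0.07 log units; that floor lies within the scatter), so the change has no readable size beyond the scatter. The steps that join two limits, methyl to trifluoromethyl among them, cannot be read.

Going by these compounds, whether an amine or a carboxylic acid on this aromatic carbon would give a measured number stays open. So does whether a methoxy group would keep the number that hydroxy gives.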